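This account rests on a few compounds, and the source may have more. Where it says the series, first, only, none or still open, it means among the compounds named here.

Within the data shown here, in a physicochemical assay for acid dissociation, only two numbers are available so far: compound 1 `COC1CCN(C(=O)c2ccc3cc(OC4CCN(C(C)C)CC4)ccc3c2)CC1` gives 9.4 and compound 2 `COC1CCN(C(=O)c2ccc3cc(OCCCN4CCCCC4)ccc3c2)CC1` gives 9.57 on the same scale. Among the measured compounds shown here, compound 2 therefore stands within the scatter of compound 1, its only neighbour on these numbers. For the measured compounds named here, the single measured step is a number 0.17 log units higher from compound 1 to compound 2 (within the scatter) and it comes with 3-(piperidin-1-yl)propyl in place of 1-isopropylpiperidin-4-yl on an oxygen on an aromatic ring.

Compound 3 `O=C(c1ccc2cc(OCCCN3CCCCC3)ccc2c1)N1CCC(CO)CC1` has not yet been measured. Its difference from compound 2 is hydroxymethyl in place of methoxy on a saturated ring carbon with hydroxymethyl in place of methoxy on a saturated ring carbon, three ring bonds from the ring nitrogen. Going by the values given here, no measured step covers this place, so the data give no direct reading of this exchange. Among the compounds with values here, the one step available, at another place, stayed within the scatter, and no shift beyond the scatter is expected in this assay for the new change. Within the data shown here, the expected size is a number 0.02 log units lower from compound 2 to compound 3 (within the scatter) and this amounts to no real step. For compound 3 the estimate is 9.55 with 9.25 to 9.85 as its expected range.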

Compound 3, acid dissociation constant: 9.6
Compound 3: middle estimate off by 0.05 log units, on the low side, and the stated range covers the measured number.
By their numbers in this assay, from the lowest: compounds 1, 2 and 3 (each within the scatter of the next).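

In this assay, this position now has a reading of its own: hydroxymethyl in place of methoxy on a saturated ring carbon, three ring bonds from the ring nitrogen, gives a number 0.03 log units higher from compound 2 to compound 3 (within the scatter). Among these compounds, the two groups have the same atoms joined differently, and the entering group carries one hydrogen-bond donor where the leaving group has none, yet this change produces no real step, just as the change on the oxygen on an aromatic ring gave a number 0.17 log units higher from compound 1 to compound 2 (within the scatter), so both places examined so far show only steps within the scatter. No supporting measurement is available to explain this result.

Still open, going by these compounds, is whether an amine or a carboxylic acid on this saturated ring carbon, or a longer chain ending in a hydroxyl group in place of hydroxymethyl, would also stay within the scatter in this assay. Also open, on these data alone, is whether the exchange of methoxy for hydroxymethyl reads the same when 1-isopropylpiperidin-4-yl, rather than 3-(piperidin-1-yl)propyl, sits on the oxygen of the shared core.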